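Cyclohexyl for cyclopentyl on the core of compound 1

The compounds below may be only part of what the source reports. "The series", "measured", "known", "first", "only" and "open" are said of these compounds alone.

Compounds measured in an ADME assay on microsomes from liver (Homo sapiens) for metabolic stability, read by LC-MS, using NADPH, with a stated time of 10 min, tested at 10 uM; on this read-out lower numbers stand for a shorter-lived compound and higher numbers for a longer-lived compound:
- compound 1, `Nc1ncnc2c1c(Oc1cc(C(F)(F)F)ccn1)nn2C1CCCC1`: 0.333 h
- compound 2, `N#Cc1ccnc(Oc2nn([C@H]3C[C@H](O)C3)c3ncnc(N)c23)c1`: > 2.41 h
- compound 3, `N#Cc1ccnc(Oc2nn([C@H]3C[C@@H](O)C3)c3ncnc(N)c23)c1`: > 2.41 h

For the measured compounds named here, compound 1 stands as the only plain number among the three results in this assay. For compound 2 the result is a limit of the assay, > 2.41 h. For compound 3 the result is likewise a limit, > 2.41 h. The step that the two limits leave unreadable from compound 2 to compound 3 cannot be read because of the limit of > 2.41 h in this assay, at which 2 of the 3 values shown sit, even though the two compounds are related by the fact that compounds 2 and 3 differ only in the configuration as drawn.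

The unmeasured compound 4, `Nc1ncnc2c1c(Oc1cc(C(F)(F)F)ccn1)nn2C1CCCCC1`, differs from compound 1 by cyclohexyl in place of cyclopentyl on an aromatic nitrogen. Neither measured step bears on this change: the one step shown concerns configuration alone in a different pair, and its size is not readable. Going by the values given here, no expectation about the step can therefore be drawn from the measured pairs.

With nothing pointing either way, the half-life of compound 4 in this assay is expected to sit near that of compound 1, the step of a 1.2-fold lower number from compound 1 to compound 4 (0.08 log units; within the scatter) being expected to stay within the usual scatter. Compound 4 is estimated at 0.28 h, with a range from 0.1 h to 0.75 h.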

Compound 4, half-life: 0.55 h
For compound 4 the middle estimate is 2.0-fold (0.29 log units) below the measured one, and the stated range covers the measured number.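

In this assay, the change gives a 1.7-fold higher number from compound 1 to compound 4 (0.22 log units; within the scatter). On an aromatic nitrogen of a five-membered aromatic ring with 2 nitrogen, one six-membered non-aromatic ring of carbon only therefore reads the same as one five-membered non-aromatic ring of carbon only, so this pair does not separate the two groups. For the compounds shown here, this is the first readable step in the set and the first to concern this position, as the only earlier step, between compound 2 and compound 3, cannot be read and deals with configuration alone. Nothing at hand explains how the half-life responds to this change at this position.

The compounds shown leave open whether a group of another kind on this nitrogen, such as a methyl group, a longer alkyl chain or a piperidine ring, would give a half-life that differs from that of compound 1 by more than the usual scatter. They also leave open whether cyclohexyl and cyclopentyl would still read alike if a nitrile took the place of the trifluoromethyl group on the otherwise unchanged core of compound 4.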